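Methyl for Methoxy on a Shared Quinolinone-Type Core

A few compounds are considered here, and "the series" means these few. Any claim that something is new, unique, unknown or untested is made for them only; others in the source may bear on it.

Three compounds share one core and were read in a functional assay on BEL-7404 cells for cytotoxicity against BEL-7404 tumor cell line (Homo sapiens), read by MTT assay, with a stated time of 48 h; a higher number here means a weaker inhibitor, a lower number a stronger inhibitor. Compound 3 `COc1ccc2[nH]c(=O)c(-c3nc4cc(C)c(C)cc4[nH]3)cc2c1` carries a methoxy group on an aromatic carbon. In this assay compound 3 gives only a limit, > 100000 nM, and no number. Compound 1 `Cc1ccc2[nH]c(=O)c(-c3nc4cc([N+](=O)[O-])ccc4[nH]3)cc2c1` also gives only a limit in this assay, > 100000 nM. Compound 2 `O=c1[nH]c2ccccc2cc1-c1nc2cc(Br)ccc2[nH]1` gives a numerical reading of 14500 nM in this assay. Two of the three values thus sit at the edge of what the assay can report, (the limit of > 100000 nM in this assay, at which 2 of the 3 values shown sit), so compound 3 stands at the weak end of the measured set together with compound 1, with no number to compare.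

Compound 4 `Cc1ccc2[nH]c(=O)c(-c3nc4cc(C)c(C)cc4[nH]3)cc2c1` differs from compound 3 in one place: methyl in place of methoxy on an aromatic carbon. For the measured compounds named here, no pair of measured compounds shows this exchange, so it has no direct precedent here. Because compound 3 gives > 100000 nM, the expected step from compound 3 to compound 4 is a number no higher from compound 3 to compound 4 (the limit leaves the size open), nothing beyond the usual scatter, with a fair chance that the assay again reports only a limit. Compound 4 is estimated at 100000 nM, within a range from 30000 nM to 300000 nM.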

Compound 4, half-maximal inhibitory concentration: > 100000 nM
Compound 4 gave a limit, no number; the forecaster's own chance of this, stated with the estimate: 70%; the middle value lies on the limit itself.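

Compound 3 and compound 4 both give only a limit and no number, so no step between them can be read: the limit of > 100000 nM in this assay, at which 3 of the 4 values shown sit.

The compounds shown leave open whether methyl in place of methoxy on an aromatic carbon changes the reading at all, and in which direction.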